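Hydroxy step on a compound at the assay limit

The compounds below may be only part of what the source reports. "The series", "measured", "known", "first", "only" and "open" are said of these compounds alone.

Measured in a functional assay on MIA PaCa-2 cells (Homo sapiens) for antiproliferative activity, read by MTT assay, with a stated time of 24 h; on this read-out higher numbers stand for weaker inhibition and lower numbers for stronger inhibition:
compound 1 `COc1ccc(-c2noc(-c3ccccc3)n2)cc1OC1CCCC1` gives > 1000000 nM, a limit
compound 2 `COc1ccc(-c2noc(Cc3c[nH]c4ccccc34)n2)cc1OC1CCCC1` gives 9560 nM, a number
compound 3 `Fc1ccc(-c2nc(-c3ccccc3)no2)cc1` gives > 1000000 nM, a limit

Within the data shown here, compound 1 has no number of its own and sits at the limit of > 1000000 nM in this assay, at which 2 of the 3 values shown sit, as its only reading. Among the measured compounds shown here, compound 2 is the only compound here with a measured number, and at 9560 nM it shows that the series can read inside the range of this assay.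

Compound 4 `COc1ccc(-c2noc(-c3ccc(O)cc3)n2)cc1OC1CCCC1` differs from compound 1 in one place. The change is hydroxy in place of hydrogen on an aromatic carbon, which turns phenyl to 4-hydroxyphenyl. For the measured compounds named here, no measured step covers this change, so the expectation is loose. A modest gain in inhibition is expected, and the reading may well stay at the limit. The estimated step of an at least 5.0-fold lower number from compound 1 to compound 4 (0.69 log units; beyond the scatter) is in the direction of stronger inhibition. For compound 4 the expected value is 200000 nM, with an estimated range of 20000 nM to 1000000 nM as the working bounds.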

Compound 4, half-maximal inhibitory concentration: 480 nM
Estimate against measurement, compound 4: 420-fold (2.62 log units) above; the measured number lies below the stated range.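

The phenyl end of the series is not a dead end: hydroxy in place of hydrogen on an aromatic carbon gives an at least 2000-fold lower number from compound 1 to compound 4 (3.31 log units; beyond the scatter) in this assay. This position, para to a large group, therefore responds strongly to a change of one heavy atom, which moves the reading from a limit to a measured number. The size of the step is a bound and not a measured gap, because one end of it rests on a limit: the limit of > 1000000 nM in this assay, at which 2 of the 4 values shown sit.

The compounds shown leave open whether this gain is specific to hydroxy or would also appear with methoxy, an amine or a carboxylic acid on the same carbon. They also leave open whether the same hydroxy step would hold on a different compound of the series, such as compound 3.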